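Chromone amides: step from compound 2 to compound 3

The compounds below may be only part of what the source reports. "The series", "measured", "known", "first", "only" and "open" are said of these compounds alone.

Measured so far:
compound 1 `COc1cc2oc(-c3ccc(NC(=O)c4ccc(Cl)cc4)cc3)cc(=O)c2c(OC)c1OC` — <= 42.6%
compound 2 `COc1cc2oc(-c3cccc(NC(=O)c4cccc(Br)c4)c3)cc(=O)c2c(O)c1OC` — 82.6%

Among the compounds with values here, compound 2 is the only compound of the pair with a number in a functional assay on RPMI-8226 cells (Homo sapiens) for inhibition, read by sulforhodamine B assay, tested at 10 uM (a higher number here means more inhibition at the concentration tested (going by the name of the read-out), a lower number less inhibition), and gives 82.6%. For compound 1 the result is a limit of the assay, <= 42.6% (the limit of <= 42.6% in this assay, at which 1 of the 2 values shown sits). No step between measured compounds is shown.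

Compound 3 `COc1cc2oc(-c3cccc(C(=O)Nc4ccc(C#N)cc4)c3)cc(=O)c2c(O)c1OC` differs from compound 2 by (4-cyanophenyl)carbamoyl in place of ((3-bromophenyl)carbonyl)amino on an aromatic carbon. Nothing measured speaks to this change, so a step of moderate size downward, beyond the scatter, is expected in this assay, though a result within the scatter cannot be excluded. Compound 3 is estimated at 60% (range 30% to 85%), the expected step being a number 22.6 percentage points lower from compound 2 to compound 3 (beyond the scatter).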

Compound 3, a percentage reported as inhibition, at one concentration (the size of the read-out at that concentration, not a potency): 82.6%
Beside the measured number, compound 3's estimate is 22.6 percentage points below it; the measured number falls inside the stated range.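

In this assay, (4-cyanophenyl)carbamoyl in place of ((3-bromophenyl)carbonyl)amino on this aromatic carbon gives no change at the digits printed from compound 2 to compound 3 (within the scatter). At the one concentration tested, this position therefore carries either of these two aryl amide groups with the same read-out, even though the amide direction and the ring substituent change together. Nothing measured bears on why the read-out holds.

From the compounds shown here alone, whether either change alone would move the read-out stays open, as does the outcome with an amine or a carboxylic acid on this carbon. A read-out at one concentration also leaves the potency of both compounds unresolved.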